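Aryl swap on the fused core: cytotoxicity notes

The compounds below may be only part of what the source reports. "The series", "measured", "known", "first", "only" and "open" are said of these compounds alone.

In an ADME assay on HEL cells (Homo sapiens) for cytotoxicity, with a stated time of 3 days (on this read-out lower numbers stand for higher toxicity in this test and higher numbers for lower toxicity in this test), compound 1 `Cc1cc(-c2cccc(F)c2)c2ncc(CSCCc3ccccc3)n2c1` gives 35 ug/mL, and compound 2 `c1ccc(CCSCc2cnc3ccc(-c4ccccc4)cn23)cc1` gives 9.9 ug/mL. Compound 3 `Cc1cc(-c2ccsc2)cn2c(CSCCc3ccccc3)cnc12` is reported in this assay only as a limit, > 50 ug/mL, not as a number. Within the data shown here, compound 3 is the single value sitting at the limit of > 50 ug/mL in this assay, at which 1 of the 3 values shown sits.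

Compound 4 `Cc1cc(-c2ccccc2O)cn2c(CSCCc3ccccc3)cnc12` differs from compound 3 by 2-hydroxyphenyl in place of thiophen-3-yl on an aromatic carbon. Among the measured compounds shown here, no measured step ends at compound 3, so its real position above the limit is open. The two compounds bearing a six-membered carbon-only aryl at this position, compound 1 and compound 2, both sit below the limit, which sets the direction. The step of an at least 1.6-fold lower number from compound 3 to compound 4 (0.22 log units; that floor lies within the scatter) is expected to run toward greater toxicity, beyond the usual scatter. Compound 4 is estimated at 30 ug/mL, with a range of 10 ug/mL to 50 ug/mL.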

Compound 4, half-maximal cytotoxic concentration: > 50 ug/mL
Compound 4: a limit, no number (the forecaster's own chance of this, stated with the estimate: 30%); middle value at least 1.6-fold (0.22 log units) from the limit.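

In this assay no step can be read between compound 3 and compound 4, because both are reported only at the same limit: the limit of > 50 ug/mL in this assay, at which 2 of the 4 values shown sit.

The compounds shown leave open whether 2-hydroxyphenyl and thiophen-3-yl differ at all on this read-out.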